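The source may hold more compounds than are shown below. What is called first, only, known or untested is meant among the compounds shown, and "the series" means these compounds.

In a functional assay on PANC-1 cells (Homo sapiens) for antiproliferative activity, read by MTT assay, with a stated time of 48 h (a higher number here means a weaker inhibitor, a lower number a stronger inhibitor), three amides built on a shared core have been measured. Compound 1 (`Cc1c(C(=O)NCCS(C)(=O)=O)oc2ccc(N(Cc3ccc(Br)cc3)S(=O)(=O)c3ccc(Br)cc3)cc12`) gives > 40000 nM, which is a limit. Among the compounds with values here, compound 2 (`Cc1c(C(=O)NCC(O)CO)oc2ccc(N(Cc3ccc(Br)cc3)S(=O)(=O)c3ccc(Br)cc3)cc12`) gives 29300 nM, the only actual number among the three. Compound 3 (`Cc1ccc(NC(=O)c2oc3ccc(N(Cc4ccc(Br)cc4)S(=O)(=O)c4ccc(Br)cc4)cc3c2C)nc1`) gives > 40000 nM, also a limit, so it stands at the limit of > 40000 nM in this assay, at which 2 of the 3 values shown sit.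

Compound 4 (`Cc1c(C(=O)NCCNc2ccccc2)oc2ccc(N(Cc3ccc(Br)cc3)S(=O)(=O)c3ccc(Br)cc3)cc12`) differs from compound 3 on the amide-type nitrogen, with 2-anilinoethyl in place of 5-methylpyridin-2-yl on an amide-type nitrogen.

The measured steps all involve changes at this same nitrogen. They are an at least 1.3-fold lower number from compound 1 to compound 2 (0.13 log units; that floor lies within the scatter), an at least 1.3-fold higher number from compound 2 to compound 3 (0.13 log units; that floor lies within the scatter) and a step that the two limits leave unreadable from compound 1 to compound 3. None of them shows a change beyond the scatter, so they give no support for a large move in this assay. The step expected is therefore an at least 1.2-fold lower number from compound 3 to compound 4 (0.09 log units; that floor lies within the scatter), with no change beyond the scatter expected. The estimate stays close to the limit of compound 3. It also stays close to the value of compound 2 at 29300 nM. The expected value for compound 4 is 32000 nM, with an estimated range from 14000 nM to 40000 nM.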

Compound 4, half-maximal inhibitory concentration: > 40000 nM
Compound 4: only a limit was reported; the forecaster's own chance of this, stated with the estimate: 55%; middle value at least 1.2-fold (0.09 log units) away from the limit.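

In this assay compound 4 gives > 40000 nM, which is a limit. Within the data shown here, the one step that can be read is an at least 1.3-fold higher number from compound 2 to compound 4 (0.13 log units; that floor lies within the scatter), and the other new steps cannot be read. Placing an aromatic ring at the end of a chain on the amide-type nitrogen, as 2-anilinoethyl does, therefore produced no measurable value, and compound 2 remains the only one of the series with an actual number: the limit of > 40000 nM in this assay, at which 3 of the 4 values shown sit.

No step shown goes beyond the scatter, and whether any group on this nitrogen gives a clearly lower number stays open. Also open, on these data alone, is how a simple amine or a carboxylic acid at the end of the chain, or a longer chain carrying hydroxyl groups, would read.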